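The source may report more compounds than this note shows. Statements on the series, on what has been measured and on what is new or still open speak of the compounds shown alone.

Compound 1 `CCC(C)(C)N/C(=N\O)Nc1cccnc1` has been tested in a functional assay on the whole organism (blood, strain Wistar-Okamoto) with Rattus norvegicus as the target, with a stated time of 5 days; on this read-out lower numbers stand for an effect already at smaller amounts and higher numbers for an effect only at larger amounts of compound. Compound 1 gives only a limit there, > 20 mg/kg, and so stands at the limit of > 20 mg/kg in this assay, at which 1 of the 2 values shown sits. Compound 2 `CCC(CC)N/C(=N\O)Nc1cccnc1` gives 50 mg/kg in this assay. Among the measured compounds shown here, the one measured step, a step that the limit leaves unreadable from compound 1 to compound 2, changes the amine substituent, not the hydroxy, and its size cannot be read. Compound 3 `CCC(C)(C)N/C(=N\C(N)=O)Nc1cccnc1` differs from compound 1 by carbamoyl in place of hydroxy on a double-bonded nitrogen. For the measured compounds named here, no measured pair touches this position, so no direction can be drawn from the data. Compound 3 is expected near 40 mg/kg, within 15 mg/kg to 100 mg/kg, in this assay. For compound 3 the expected step is a step that the limit leaves unreadable from compound 1 to compound 3.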

Compound 3, minimum effective dose: > 50 mg/kg
Compound 3 ended at the assay's limit; the forecaster's own chance of this, stated with the estimate: 50%; middle value at least 1.2-fold (0.09 log units) from the limit.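

Compound 1 and compound 3 each give only a limit in this assay, and the step between them cannot be read. The compounds shown leave open whether carbamoyl in place of hydroxy changes the minimum effective dose.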